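Adding one methyl to compound 3

The source may report more compounds than this note shows. Statements on the series, on what has been measured and on what is new or still open speak of the compounds shown alone.

So far, three compounds sharing a common core have been tested in a functional assay on HepG2 cells (Homo sapiens) for antiproliferative activity, read by MTT assay, with a stated time of 72 h (a higher number here means a weaker inhibitor, a lower number a stronger inhibitor), and each result shows how much compound is needed to slow cell growth. Compound 1 `COc1ccc(N2C(=O)COc3ccc(-c4ccc(O)cc4)cc32)cc1` gives 10800 nM in this test. Compound 2 `COc1cccc(N2C(=O)COc3ccc(-c4cnc(OC)c(NS(=O)(=O)c5ccc(F)cc5)c4)cc32)c1` gives > 40000 nM and this is a limit, not a number. Compound 3 `O=C1COc2ccc(-c3cccc(NS(=O)(=O)c4ccc(F)cc4)c3)cc2N1c1ccccc1` gives 30300 nM and so holds the higher of the two actual numbers, which makes it the weaker of the pair, and its gap to compound 1 lies beyond the usual scatter.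

Compound 4 `Cc1ccc(N2C(=O)COc3ccc(-c4cccc(NS(=O)(=O)c5ccc(F)cc5)c4)cc32)cc1` differs from compound 3 in one place methyl in place of hydrogen on an aromatic carbon and this turns phenyl into 4-methylphenyl. For the measured compounds named here, no measured pair shows this change alone, so no step beyond the scatter is expected in this assay for this single addition. The expected change is small, an estimated 1.2-fold lower number from compound 3 to compound 4 (0.08 log units; within the scatter) and no more. Compound 4 is estimated at 25000 nM (range 12000 nM to 40000 nM).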

Compound 4, half-maximal inhibitory concentration: > 40000 nM
Compound 4: only a limit was reported (the forecaster's own chance of this, stated with the estimate: 25%); middle value at least 1.6-fold (0.20 log units) away from the limit.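

For the compounds shown here, this is the first pair in this assay that isolates a single change, phenyl to 4-methylphenyl, with the methyl para to a large group, and the step reads an at least 1.3-fold higher number from compound 3 to compound 4 (0.12 log units; that floor lies within the scatter). The result for compound 4, > 40000 nM, is a limit and not a number. The methyl therefore brought no sign of the lower number that a stronger inhibitor would give, but the true size of the step stays unknown because compound 4 sits at this limit: the limit of > 40000 nM in this assay, at which 2 of the 4 values shown sit.

As far as these compounds go, how far compound 4 truly lies from compound 3 remains open. Also open, from the compounds shown here alone, is whether a different group at this position, such as an amine, a carboxylic acid or a longer chain, would give a lower number in this assay.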